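Sulfonyl substituent variation on the indole enone series

The source may report more compounds than this note shows. Statements on the series, on what has been measured and on what is new or still open speak of the compounds shown alone.

Three measured compounds share one core and differ only in the group on a sulfonyl sulfur whose other neighbour is an aromatic nitrogen. In a functional assay on MCF7 cells (Homo sapiens) for antiproliferative activity, read by MTT assay, with a stated time of 48 h (on this read-out lower numbers stand for stronger inhibition and higher numbers for weaker inhibition), compound 1 `O=C(/C=C/c1cn(S(=O)(=O)c2ccc(Cl)cc2)c2ccccc12)c1ccncc1` gives 37500 nM. Compound 2 `CCCS(=O)(=O)n1cc(/C=C/C(=O)c2ccncc2)c2ccccc21` gives 52400 nM in this assay, and compound 3 `O=C(/C=C/c1cn(S(=O)(=O)c2ccccc2[N+](=O)[O-])c2ccccc12)c1ccncc1` gives 36900 nM. Compound 3 holds the lowest number of the three, but the two steps that lead to it, a 1.0-fold lower number from compound 1 to compound 3 (0.01 log units; within the scatter) and a 1.4-fold lower number from compound 2 to compound 3 (0.15 log units; within the scatter), are both within the scatter, so no order among them can be claimed. The remaining step, a 1.4-fold higher number from compound 1 to compound 2 (0.15 log units; within the scatter), is likewise within the scatter.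

Compound 4 `COc1ccc(S(=O)(=O)n2cc(/C=C/C(=O)c3ccncc3)c3ccccc32)cc1` is the next member; it differs from compound 3 in this way: 4-methoxyphenyl in place of 2-nitrophenyl on a sulfonyl sulfur. All three measured steps exchange one group on the same sulfonyl sulfur, and each of them stayed within the scatter, so a fourth exchange at that position is expected to do the same. Among the measured compounds shown here, no step in this assay beyond the scatter is available to argue for a direction in either sense.

For compound 4 in this assay the expected value is 40000 nM, with a range from 18000 nM to 90000 nM. The expected step from compound 3 is therefore a 1.1-fold higher number from compound 3 to compound 4 (0.04 log units; within the scatter), within the scatter.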

Compound 4, half-maximal inhibitory concentration: 65800 nM
For compound 4 the middle estimate is 1.6-fold (0.22 log units) below the measured one; measured number inside the range.
By their numbers in this assay, from the lowest: compounds 3, 1, 2 and 4 (each within the scatter of the next).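

In this assay the exchange of 2-nitrophenyl for 4-methoxyphenyl on the sulfonyl sulfur gives a 1.8-fold higher number from compound 3 to compound 4 (0.25 log units; within the scatter) and so adds one more step within the scatter, as does the exchange of propyl for 4-methoxyphenyl, with a 1.3-fold higher number from compound 2 to compound 4 (0.10 log units; within the scatter) as its step. The new information is the pair of compounds 1 and 4, the first to keep the phenyl group on the sulfur and alter only its substituent: methoxy in place of chloro on an aromatic carbon gives a 1.8-fold higher number from compound 1 to compound 4 (0.24 log units; within the scatter) and also stays within the scatter, so across propyl and the three substituted phenyl groups this position shows no order, and no measurement offers an explanation for the values seen here.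

Whether any group on this sulfonyl sulfur can move the number beyond the scatter remains open, since an amine or a carboxylic acid on the phenyl group, or a chain longer than propyl, does not appear among these compounds. The compounds shown also say nothing about changes elsewhere on the shared core, since all of them keep it intact.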